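Moving the methyl on the aryl ring: working notes

A few compounds are considered here, and "the series" means these few. Any claim that something is new, unique, unknown or untested is made for them only; others in the source may bear on it.

Measured so far:
compound 1, `CCn1nc(C)c2c1CCN(C(C(=O)NC)c1ccccc1)C2CCc1cccc(F)c1`, 402 nM in a functional assay on CHO cells for antagonist activity at Orexin/Hypocretin receptor type 1 (Homo sapiens), read by FLIPR and calcium flux; on this read-out higher numbers stand for weaker inhibition and lower numbers for stronger inhibition
compound 2, `CCn1nc(C)c2c1CCN(C(C(=O)NC)c1ccccc1)C2CCc1ccc(C)cc1`, 108 nM in this assay

Compound 2 holds the lowest of the two numbers in this assay; compound 1 sits at a 3.7-fold lower number from compound 1 to compound 2 (0.57 log units; beyond the scatter) from it. Compound 3 is `CCn1nc(C)c2c1CCN(C(C(=O)NC)c1ccccc1)C2CCc1cccc(C)c1`. Against compound 2 the change is 3-methylphenyl in place of 4-methylphenyl on a saturated chain carbon, two bonds along the chain from a saturated ring carbon. Among the compounds with values here, the only measured step, a 3.7-fold lower number from compound 1 to compound 2 (0.57 log units; beyond the scatter), changes both the group and its place at once, so it bears only loosely here. The step is expected to be modest and toward a higher number, a 1.9-fold higher number from compound 2 to compound 3 (0.27 log units; within the scatter). Compound 3 is thus estimated at 200 nM in this assay, within 80 nM to 500 nM.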

Compound 3, half-maximal inhibitory concentration: 180 nM
The estimate for compound 3 lay 1.1-fold (0.05 log units) above the measured number; low and high end bracket the measured number.
By their numbers in this assay, from the lowest: compounds 2 and 3 (each within the scatter of the next); then compound 1.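

Moving the methyl, 3-methylphenyl in place of 4-methylphenyl, gives a 1.7-fold higher number from compound 2 to compound 3 (0.22 log units; within the scatter) in this assay, so these two groups are not separated on this read-out. Methyl in place of fluoro on an aromatic carbon can now be read as a single change, a 2.2-fold lower number from compound 1 to compound 3 (0.35 log units; beyond the scatter), so among these compounds the exchange of fluoro for methyl, not the move of the methyl, carries a step beyond the scatter. Nothing at hand explains either step.

On these data alone, whether methoxy or an amine on this aromatic ring would lower or raise the number remains open. So does the effect of a longer chain in place of the 2-(3-methylphenyl)ethyl group.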